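The compounds below may be only part of what the source reports. "The series", "measured", "known", "first", "only" and "open" are said of these compounds alone.

Compound 1, `CCCCNc1nc(N)nc2c1CN(C)CC2`, carries a methyl on an amine nitrogen in a ring; in an assay on HEK293 cells for agonist activity at Toll-like receptor 8 (Homo sapiens), read by a luciferase reporter, with a stated time of 6 h (a lower number here means that less compound is needed, a higher number that more compound is needed for the effect), compound 1 gives 0.03 uM. Compound 2, `CCCCNc1nc(N)nc2c1CN(C(=O)c1ccccc1)CC2`, gives 1.4 uM in this assay, a step of a 47-fold higher number from compound 1 to compound 2 (1.67 log units; beyond the scatter). Compound 3, `CCCCNc1nc(N)nc2c1CN(C(=O)c1csc(C)n1)CC2`, gives 1.8 uM in this assay, which is the highest of the three numbers; its nearest neighbour is compound 2 (a 1.3-fold higher number from compound 2 to compound 3 (0.11 log units; within the scatter)), and its furthest is compound 1 (a 60-fold higher number from compound 1 to compound 3 (1.78 log units; beyond the scatter)).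

Compound 4 is `CCCCNc1nc(N)nc2c1CN(C(=O)c1scnc1C)CC2`. It differs from compound 3 by 4-methyl-1,3-thiazol-5-yl in place of 2-methyl-1,3-thiazol-4-yl on a carbonyl carbon. Among the compounds with values here, the one measured step that bears on this is the exchange of one aromatic group for another on the same carbonyl carbon, a 1.3-fold higher number from compound 2 to compound 3 (0.11 log units; within the scatter), which stayed within the scatter. Rearranging the thiazole is a smaller change than swapping a phenyl for a thiazole, so no step beyond the scatter is expected in this assay. Compound 4 is therefore expected to give about 1.8 uM, within a range of 0.9 uM to 3.6 uM, an estimated step of no change at the digits printed from compound 3 to compound 4 (within the scatter).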

Compound 4, minimum effective concentration: 5.6 uM
Estimate against measurement, compound 4: 3.1-fold (0.49 log units) below; measured number outside the range, above it.
By their numbers in this assay, from the lowest: compound 1; then compounds 2 and 3 (each within the scatter of the next); then compound 4.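

Two thiazole groups with the same atoms, joined differently, do not behave alike on this carbonyl carbon: in this assay the change to 4-methyl-1,3-thiazol-5-yl brings a real shift (a 3.1-fold higher number from compound 3 to compound 4 (0.49 log units; beyond the scatter)), so the arrangement of the ring can matter even though the exchange of phenyl for 2-methyl-1,3-thiazol-4-yl moved nothing beyond the scatter. The new group also separates from phenyl (a 4.0-fold higher number from compound 2 to compound 4 (0.60 log units; beyond the scatter)) and lies furthest from the methyl on the amine nitrogen in a ring (a 190-fold higher number from compound 1 to compound 4 (2.27 log units; beyond the scatter)), which widens the gap between the carbonyl-linked groups and methyl. Nothing shown here explains why this rearranged thiazole needs more compound.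

Still open, from the compounds shown here alone, is whether an unsubstituted thiazole or a pyridine ring on the carbonyl carbon would sit nearer compound 2 or compound 4. Going by these compounds, it is also open whether an ethyl group on the amine nitrogen in a ring would stay close to compound 1.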